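A few compounds are considered here, and "the series" means these few. Any claim that something is new, unique, unknown or untested is made for them only; others in the source may bear on it.

In an ADME assay on HUVEC cells (Homo sapiens) for inhibition, read by CCK-8 assay, with a stated time of 24 h, in the presence of a further agent that is not named here (on this read-out higher numbers stand for weaker inhibition and lower numbers for stronger inhibition), compound 1 `Cc1ccc(-n2cc(-c3ccc(/C=C4\C(=O)Nc5ccc(F)cc54)cc3)nn2)cc1` gives 13800 nM and compound 3 `O=C1Nc2ccc(F)cc2/C1=C/c1ccc(-c2cn(-c3ccccc3Cl)nn2)cc1` gives 18200 nM, two values within the scatter of each other. Compound 2 `O=C1Nc2ccc(F)cc2/C1=C/c1ccc(-c2cn(-c3ccc(F)cc3)nn2)cc1` gives > 20000 nM, which is a limit of the assay and not a number. Compound 4 `O=C1Nc2ccc(F)cc2/C1=C/c1ccc(-c2cn(-c3cccc(Cl)c3)nn2)cc1` carries 3-chlorophenyl in place of 2-chlorophenyl on an aromatic nitrogen. The measured changes at that place are a 1.3-fold higher number from compound 1 to compound 3 (0.12 log units; within the scatter), an at least 1.0-fold lower number from compound 2 to compound 3 (0.04 log units; that floor lies within the scatter) and an at least 1.4-fold higher number from compound 1 to compound 2 (0.16 log units; that floor lies within the scatter), and all of them stay within the scatter. No step beyond the scatter is therefore expected in this assay, and the estimated step is a 1.1-fold lower number from compound 3 to compound 4 (0.03 log units; within the scatter). For compound 4 the estimated value is 17000 nM, with an expected range of 10000 nM to 27000 nM.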

Compound 4, half-maximal inhibitory concentration: 19400 nM
For compound 4 the middle estimate is 1.1-fold (0.06 log units) below the measured one; the range from low to high includes it.
By their numbers in this assay, from the lowest: compounds 1, 3 and 4 (each within the scatter of the next). At a limit, above all of these: compound 2.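

In this assay, 3-chlorophenyl in place of 2-chlorophenyl gives a 1.1-fold higher number from compound 3 to compound 4 (0.03 log units; within the scatter), so changing where the chlorine sits on this aryl group produces no separation. Against the 4-methylphenyl group, the result is a 1.4-fold higher number from compound 1 to compound 4 (0.15 log units; within the scatter), again with no separation. Compound 2 stands at a limit of the assay, not a number, so an at least 1.0-fold lower number from compound 2 to compound 4 (0.01 log units; that floor lies within the scatter) gives only a floor: the limit of > 20000 nM in this assay, at which 1 of the 4 values shown sits.

The compounds shown leave open whether an amine or a carboxylic acid on this phenyl ring would give a step beyond the scatter.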